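The source may hold more compounds than are shown below. What is called first, only, known or untested is meant among the compounds shown, and "the series" means these compounds.

Measured in an assay on RBL-1 cells for inhibition of Polyunsaturated fatty acid 5-lipoxygenase (Rattus norvegicus); a higher number here means a weaker inhibitor, a lower number a stronger inhibitor:
- compound 1 `COc1cc(/C=C/C=C/c2nc3ccccc3o2)ccc1O`: 330 nM
- compound 2 `CCOC(=O)c1ccc2oc(/C=C/C=C/c3ccc(O)c(OC)c3)nc2c1`: 250 nM
- compound 3 `Oc1ccc(/C=C/C=C/c2nc3ccccc3o2)cc1O`: 30 nM

Among the compounds with values here, compound 3 stands lowest of the three numbers; the gap to compound 1 is given by an 11-fold lower number from compound 1 to compound 3 (1.04 log units; beyond the scatter), the single step that moved the number beyond the scatter, and the value of compound 2 lies between those of compound 1 and compound 3 but closer to compound 1.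

Compound 4 `CCOC(=O)c1ccc2oc(/C=C/C=C/c3ccc(O)c(O)c3)nc2c1` differs from compound 3 by ethoxycarbonyl in place of hydrogen on an aromatic carbon. Within the data shown here, the one measured step that bears on this change is a 1.3-fold lower number from compound 1 to compound 2 (0.12 log units; within the scatter), the same group entering at the same place on the core with the methyl still on the oxygen; that step stayed within the scatter. Nothing in the series suggests the group behaves differently once the methyl is gone, so in this assay no step beyond the scatter is expected for compound 4, at most a slight drift downward as a 1.2-fold lower number from compound 3 to compound 4 (0.08 log units; within the scatter). For compound 4 the expected value is 25 nM, with a range from 10 nM to 70 nM.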

Compound 4, half-maximal inhibitory concentration: 20 nM
Compound 4: middle estimate off by 1.3-fold (0.10 log units), on the high side; the range from low to high includes it.
By their numbers in this assay, from the lowest: compounds 4 and 3 (each within the scatter of the next); then compounds 2 and 1 (each within the scatter of the next).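

In this assay, ethoxycarbonyl in place of hydrogen on the aromatic carbon also stays within the scatter when the oxygen carries hydrogen rather than methyl, with a 1.5-fold lower number from compound 3 to compound 4 (0.18 log units; within the scatter), so the earlier result is not confined to the methyl ether: the same change on two cores in this assay, a 1.3-fold lower number (0.12 log units; within the scatter) from compound 1 to compound 2 and a 1.5-fold lower number (0.18 log units; within the scatter) from compound 3 to compound 4, 1.1-fold (0.06 log units) apart, within the scatter of two such steps. The large effect of hydrogen in place of methyl on that oxygen also persists with ethoxycarbonyl present, with a 13-fold lower number from compound 2 to compound 4 (1.10 log units; beyond the scatter): the same change on two cores in this assay, an 11-fold lower number (1.04 log units; beyond the scatter) from compound 1 to compound 3 and a 13-fold lower number (1.10 log units; beyond the scatter) from compound 2 to compound 4, 1.1-fold (0.06 log units) apart, within the scatter of two such steps. Across these four compounds the two changes therefore read as independent, and no compound goes against this.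

Ethoxycarbonyl is the only group shown at this carbon, so whether a carboxylic acid or an amine there would also stay within the scatter remains open. Also open, going by these compounds, is whether an ethyl group on the oxygen would give a step like that of methyl.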